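Swapping Dimethylamino for Chloro on the Aryl Ring

A few compounds are considered here, and "the series" means these few. Any claim that something is new, unique, unknown or untested is made for them only; others in the source may bear on it.

Among the measured compounds shown here, compound 2 `CN(C)c1ccc(-c2nc(NN)n(C)c(=O)c2C#N)cc1` gives 69 ug/mL in a functional assay, with a stated time of 150 min (a higher number here means a weaker inhibitor, a lower number a stronger inhibitor), the higher of only two numbers measured so far, yet the step of a 1.2-fold higher number from compound 1 to compound 2 (0.09 log units; within the scatter) from compound 1 `COc1ccc(-c2nc(NN)n(C)c(=O)c2C#N)cc1`, which gives 56 ug/mL, lies within the scatter. Compound 3 `Cn1c(NN)nc(-c2ccc(Cl)cc2)c(C#N)c1=O` differs from compound 2 by chloro in place of dimethylamino on an aromatic carbon. For the measured compounds named here, the single measured step at this position, a 1.2-fold higher number from compound 1 to compound 2 (0.09 log units; within the scatter), was small, so a further swap there is expected to shift this assay little, with no direction favoured. Compound 3 is therefore estimated at 60 ug/mL, between 30 ug/mL and 120 ug/mL, an expected step of a 1.2-fold lower number from compound 2 to compound 3 (0.06 log units; within the scatter).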

Compound 3, half-maximal inhibitory concentration: 59 ug/mL
Estimate against measurement, compound 3: 1.0-fold (0.01 log units) above; the measured number falls inside the stated range.
By their numbers in this assay, from the lowest: compounds 1, 3 and 2 (each within the scatter of the next).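

Chloro brings only 1 heavy atom and no hydrogen-bond acceptor in place of dimethylamino, yet this assay shows a 1.2-fold lower number from compound 2 to compound 3 (0.07 log units; within the scatter). Against methoxy the picture is the same, with a 1.1-fold higher number from compound 1 to compound 3 (0.02 log units; within the scatter). Across these three groups, this position has so far shown no separation in this assay, and no evidence is available to explain that. Going by these compounds, whether a carboxylic acid or a longer chain here would move the number remains open. So does whether changes elsewhere on the shared core would matter more.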